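Shifting a methoxy group on an aryl substituent

This account rests on a few compounds, and the source may have more. Where it says the series, first, only, none or still open, it means among the compounds named here.

Measured so far:
- compound 1 `CC(C)(C)Cc1c(-c2ccoc2)sc(N)c1C(=O)c1ccc(Cl)cc1`: 1%
- compound 2 `CC(C)(C)Cc1c(-c2ccc(F)cc2)sc(N)c1C(=O)c1ccc(Cl)cc1`: 1%
- compound 3 `COc1cccc(-c2sc(N)c(C(=O)c3ccc(Cl)cc3)c2CC(C)(C)C)c1`: 1%

In an assay on CHO cells for displacement of a labelled ligand from adenosine receptor A1 (Homo sapiens), read by scintillation counting, tested at 10 uM (on this read-out lower numbers stand for less inhibition and higher numbers for more inhibition at the one concentration tested (going by the name of the read-out)), compound 1 gives 1%, and all three measured compounds sit at the same low level: no change at the digits printed from compound 1 to compound 2 (within the scatter), no change at the digits printed from compound 1 to compound 3 (within the scatter) and no change at the digits printed from compound 2 to compound 3 (within the scatter). Compound 3 therefore stands level with compounds 1 and 2, with nothing to set it apart.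

Compound 4 `COc1ccc(-c2sc(N)c(C(=O)c3ccc(Cl)cc3)c2CC(C)(C)C)cc1` differs from compound 3 in one place: 4-methoxyphenyl in place of 3-methoxyphenyl on an aromatic carbon. Two earlier steps bear on this, since each swapped the aryl group on the same carbon; both, from compound 1 to compound 3 and from compound 2 to compound 3, left the read-out unchanged within the scatter. No step beyond the scatter is therefore expected here. For compound 4 the estimated value is 2%, ranging from 0% to 12%, an expected step of a number 1 percentage points higher from compound 3 to compound 4 (within the scatter).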

Compound 4, a percentage reported as inhibition, at one concentration (the size of the read-out at that concentration, not a potency): 1%
The estimate for compound 4 lay 1 percentage points above the measured number; low and high end bracket the measured number.
By their numbers in this assay, from the lowest: compounds 1, 2, 3 and 4 (each within the scatter of the next).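

Moving the methoxy group from 3-methoxyphenyl to 4-methoxyphenyl on this carbon makes no visible difference in this assay (no change at the digits printed from compound 3 to compound 4 (within the scatter)). Compound 4 also matches the other two aryl variants (no change at the digits printed from compound 2 to compound 4 (within the scatter); no change at the digits printed from compound 1 to compound 4 (within the scatter)), so the methoxy placement joins the aryl swaps in leaving the read-out flat at this position. No supporting data explain this flat result.
Going by these compounds, it remains open whether an amine or a carboxylic acid on the aryl ring would change the read-out, or whether a longer chain in place of the neopentyl group would.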